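Swapping Fluoro for Methoxy on Two Oxazoline-Type Cores

A few compounds are considered here, and "the series" means these few. Any claim that something is new, unique, unknown or untested is made for them only; others in the source may bear on it.

Measured so far:
compound 1, `COC(=O)[C@@H]1COC(/C=C/c2ccc(F)cc2)=N1`: 18.6%
compound 2, `COC(=O)[C@@H]1COC(/C=C/c2ccc(OC)cc2)=N1`: 20.9%
compound 3, `COC(=O)c1coc(/C=C/c2ccc(F)cc2)n1`: 99%

In an ADME assay on Vero cells (Chlorocebus sabaeus) for cytotoxicity, read by WST assay, tested at 100 ug/mL (a higher number here means a weaker effect of the compound at the concentration tested, a lower number a stronger effect), compound 1 gives 18.6% and compound 2 gives 20.9%. The two differ only by methoxy in place of fluoro on an aromatic carbon, and that change moved the read-out by a number 2.3 percentage points higher from compound 1 to compound 2 (within the scatter). Compound 3, with a different core, gives 99% in this assay; how the two cores differ is not broken down here.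

Compound 4, `COC(=O)c1coc(/C=C/c2ccc(OC)cc2)n1`, is not yet measured. It differs from compound 3 by methoxy in place of fluoro on an aromatic carbon, the same change seen from compound 1 to compound 2. Because that earlier step was a number 2.3 percentage points higher from compound 1 to compound 2 (within the scatter), and because compound 3 already gives 99%, the step from compound 3 to compound 4 is expected to be small, about a number 2 percentage points lower from compound 3 to compound 4 (within the scatter). The estimate for compound 4 in this assay is therefore 97%, likely between 85% and 100%.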

Compound 4, a percentage reported as activity, at one concentration (the size of the read-out at that concentration, not a potency): 96.8%
For compound 4 the middle estimate is 0.2 percentage points above the measured one; the measured number falls inside the stated range.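

In this assay, putting methoxy in place of fluoro on an aromatic carbon gives a number 2.2 percentage points lower from compound 3 to compound 4 (within the scatter). Set beside the earlier step, the change carries over between these two cores, with no difference that can be told apart from scatter: the same change on two cores in this assay, a number 2.3 percentage points higher (within the scatter) from compound 1 to compound 2 and a number 2.2 percentage points lower (within the scatter) from compound 3 to compound 4, 4.5 percentage points apart, within the scatter of two such steps This shows only that the swap leaves the read-out unmoved on these two cores, and it does not show that the same would hold on any other core or explain why.

The compounds shown carry only fluoro or methoxy at this place, so the effect of an amine, a carboxylic acid or a longer chain there remains open. Also open, as far as these compounds go, is which feature of the two cores matters in this assay.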